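The compounds below may be only part of what the source reports. "The series", "measured", "known", "first", "only" and "open" are said of these compounds alone.

Working notes on the series. In a functional assay on MDA-MB-468 cells (Homo sapiens) for cytotoxicity, read by sulforhodamine B assay, with a stated time of 48 h (a higher number here means a weaker inhibitor of growth, a lower number a stronger inhibitor of growth), compound 1 `Cc1ccc2nc(/N=C3\C(=O)N(CN4CCCCC4)c4ccccc43)sc2c1` gives 65600 nM, the highest of the two numbers in hand. Compound 2 `O=C1C(=O)N(CN(c2ccccc2)c2ccccc2)c2ccccc21` gives 21500 nM in this assay; the two compounds differ in more than one place, so their values are only set side by side, and the gap between them lies beyond the scatter. Compound 3 `Cc1ccc2nc(/N=C3\C(=O)N(CN(C)C)c4ccccc43)sc2c1` carries dimethylamino in place of piperidin-1-yl on a saturated chain carbon bound to an amide-type nitrogen in a ring. Among the measured compounds shown here, no step between measured compounds is available to calibrate this change. The expected shift from compound 1 is a 1.1-fold lower number from compound 1 to compound 3 (0.04 log units; within the scatter), within the scatter and in no settled direction. Compound 3 is estimated at 60000 nM in this assay, with a range from 25000 nM to 150000 nM.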

Compound 3, concentration for 50% growth inhibition: 35500 nM
Estimate against measurement, compound 3: 1.7-fold (0.23 log units) above; measured number inside the range.
By their numbers in this assay, from the lowest: compounds 2, 3 and 1 (each within the scatter of the next, the first and the last beyond it).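

Among the compounds shown here, the first measured step at this place, dimethylamino in place of piperidin-1-yl on a saturated chain carbon bound to an amide-type nitrogen in a ring, gives a 1.8-fold lower number from compound 1 to compound 3 (0.27 log units; within the scatter) in this assay. The ring of piperidin-1-yl can therefore give way to the open dimethylamino without a shift beyond the scatter. No measured evidence bears on this step.

Still open, as far as these compounds go, is whether morpholin-4-yl at this place, or a longer chain carrying the amine, would shift the number beyond the scatter.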